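This account rests on a few compounds, and the source may have more. Where it says the series, first, only, none or still open, it means among the compounds named here.

In a functional assay on HEp-2 cells (Homo sapiens) for inhibition, read by MTT assay, with a stated time of 72 h (on this read-out higher numbers stand for weaker inhibition and lower numbers for stronger inhibition), compound 1 `CCO[C@@H]1C=CC(=O)[C@@H](CO)O1` gives 5800 nM and compound 2 `CC(C)O[C@@H]1C=CC(=O)[C@@H](CO)O1` gives 34900 nM, the higher of the two numbers and so the weaker inhibition of the pair. Compound 3 `C#CCO[C@@H]1C=CC(=O)[C@@H](CO)O1` comes from compound 2 by propargyl in place of isopropyl on an oxygen on a saturated carbon, with propargyl in place of isopropyl on an oxygen on a saturated carbon. For the measured compounds named here, only one measured step bears on this change: a 6.0-fold higher number from compound 1 to compound 2 (0.78 log units; beyond the scatter), a modest step beyond the scatter, made by methyl in place of hydrogen on the saturated chain carbon bound to that oxygen. Propargyl carries no such methyl there, so a modest move back towards lower numbers is expected, though this rests on a single pair. The expected change is a 3.9-fold lower number from compound 2 to compound 3 (0.59 log units; beyond the scatter). In this assay, the estimated value for compound 3 is 9000 nM, with an expected range of 3000 nM to 28000 nM.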

Compound 3, half-maximal inhibitory concentration: 15400 nM
Compound 3: middle estimate off by 1.7-fold (0.23 log units), on the low side; low and high end bracket the measured number.
By their numbers in this assay, from the lowest: compound 1; then compound 3; then compound 2.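

In this assay, the position on the oxygen proves sensitive to more than the single methyl seen earlier. Compound 2 with isopropyl gives the weakest inhibition of the three compounds, and propargyl recovers only part of that loss, with a 2.3-fold lower number from compound 2 to compound 3 (0.36 log units; beyond the scatter), and it does not return to the level of the ethyl group. With ethynyl in place of methyl, there is a 2.7-fold higher number from compound 1 to compound 3 (0.42 log units; beyond the scatter), so an unbranched group here still gives weaker inhibition than ethyl, though the rise is smaller than a 6.0-fold higher number from compound 1 to compound 2 (0.78 log units; beyond the scatter). No measurement at hand explains why these numbers move as they do.

The compounds shown leave open whether the rise from ethyl to propargyl follows from the triple bond or from chain length, which a saturated propyl group would help to separate. Equally open, as far as these compounds go, is how a methyl group or an amine-bearing chain on this oxygen would behave.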